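Notes on compound 4: aryl exchange on the shared core

The compounds below may be only part of what the source reports. "The series", "measured", "known", "first", "only" and "open" are said of these compounds alone.

Compound 1 `N#Cc1cc(-c2nc(C(c3ccc(F)cc3)c3ccc(F)cc3)sc2CC(=O)O)ccc1F` was measured in an in vitro functional assay on HEK285-7 cells for antagonist activity at prostaglandin D2 receptor 2 (Homo sapiens), read by BRET and beta-arrestin recruitment (a higher number here means a larger maximal response, a lower number a smaller maximal response), where compound 1 gives 80%. Compound 2 `O=C(O)Cc1sc(C(c2ccc(F)cc2)c2ccc(F)cc2)nc1-c1ccco1` gives 80% in this assay, and compound 3 `O=C(O)Cc1sc(C(c2ccccc2)c2ccccc2)nc1-c1cccc(F)c1` gives 80%. Compound 1 therefore stands level with both at the digits shown; its nearest neighbour is compound 2, and the one single-point step known in this set, no change at the digits printed from compound 1 to compound 2 (within the scatter), lies within the scatter. Compound 3 differs from compound 1 in more than one place, and the two values show no difference beyond the scatter either.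

Compound 4 `CS(=O)(=O)Nc1cccc(-c2nc(C(c3ccc(F)cc3)c3ccc(F)cc3)sc2CC(=O)O)c1` is the next member to be measured. Relative to compound 1 the change is: 3-(methanesulfonamido)phenyl in place of 3-cyano-4-fluorophenyl on an aromatic carbon The only measured step that bears on this exchange is the aryl replacement at the same position, no change at the digits printed from compound 1 to compound 2 (within the scatter), which left the largest response unchanged within the scatter even though a 3-cyano-4-fluorophenyl was swapped for a furan-2-yl. With one reference step only, and that one flat, no direction is indicated for the 3-(methanesulfonamido)phenyl. The step of no change at the digits printed from compound 1 to compound 4 (within the scatter) is therefore expected to stay within the scatter. For compound 4 the estimated value in this assay is 80%, with a range from 65% to 95%.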

Compound 4, largest response reached (reported as efficacy), in percent of the reference or control that the assay uses: 80%
For compound 4 middle estimate and measured number coincide at the digits printed; the measured number falls inside the stated range.
By their numbers in this assay, from the lowest: compounds 1, 2, 3 and 4 (each within the scatter of the next).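

At the aromatic carbon next to the ring nitrogen, this assay gives no change at the digits printed from compound 1 to compound 4 (within the scatter), and the same read-out gives no change at the digits printed from compound 2 to compound 4 (within the scatter). The flat result now extends beyond the furan-2-yl exchange: 3-(methanesulfonamido)phenyl, with its sulfur, two oxygens and one hydrogen-bond donor, replaces a 3-cyano-4-fluorophenyl that has no hydrogen-bond donor, and the step still stays within the scatter, so all three groups compared on this core remain indistinguishable in largest response. No supporting evidence is available to account for this insensitivity.

On these data alone, whether any group at this position can move the largest response beyond the scatter remains open, for example a primary amine or a carboxylic acid on the phenyl ring, or a methyl group in place of the whole aryl ring. The largest response alone also leaves open whether these exchanges alter the concentration at which that response is reached, so the flat picture applies to this one read-out only.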